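The source may report more compounds than this note shows. Statements on the series, on what has been measured and on what is new or still open speak of the compounds shown alone.

Within the data shown here, the three measured members share one core. Compound 1 `CCCCCCCCCCc1ccc(-c2noc(CN)n2)cc1` gives 62% in an assay on HeLa cells for inhibition of sphingosine-1-phosphate transporter SPNS2 (Mus musculus), read by LC-MS, tested at 2 uM; a higher number here means more inhibition at the concentration tested (going by the name of the read-out), a lower number less inhibition. Compound 2 `CCCCCCCCCCc1ccc(-c2noc(CC(O)CN)n2)cc1` gives 59% in this assay, and the step of a number 3 percentage points lower from compound 1 to compound 2 (within the scatter) lies within the scatter. Compound 3 `CCCCCCCCCCc1ccc(-c2noc([C@@H](N)CCN)n2)cc1` gives 14% in this assay and stands lowest of the three, with a number 48 percentage points lower from compound 1 to compound 3 (beyond the scatter) and a number 45 percentage points lower from compound 2 to compound 3 (beyond the scatter) both large and beyond the scatter.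

Compound 4 `CCCCCCCCCCc1ccc(-c2noc(CCCN3CCCC3)n2)cc1` has not yet been measured in this assay. It differs from compound 3 by 3-(pyrrolidin-1-yl)propyl in place of 1,3-diaminopropyl on an aromatic carbon. The two measured steps into compound 3 bear directly on this change: each time the 1,3-diaminopropyl entered in place of a chain carrying an amino group, the read-out fell sharply. Removing the 1,3-diaminopropyl is therefore expected to recover much of that loss. The entering 3-(pyrrolidin-1-yl)propyl is not covered by compound 1 or compound 2, which keep an amino group, so the size of the return toward their level is uncertain.

For compound 4 a rise of about a number 36 percentage points higher from compound 3 to compound 4 (beyond the scatter) is expected. The estimate for compound 4 is 50%, with a range from 25% to 75%.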

Compound 4, a percentage reported as inhibition, at one concentration (the size of the read-out at that concentration, not a potency): 3%
For compound 4 the middle estimate is 47 percentage points above the measured one, outside the stated range (below it).
By their numbers in this assay, from the lowest: compound 4; then compound 3; then compounds 2 and 1 (each within the scatter of the next).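

In this assay the low level of compound 3 does not recover when 3-(pyrrolidin-1-yl)propyl replaces 1,3-diaminopropyl on this aromatic carbon: a number 11 percentage points lower from compound 3 to compound 4 (beyond the scatter) is a further modest fall, so losing the 1,3-diaminopropyl alone does not restore the read-out. With a number 56 percentage points lower from compound 2 to compound 4 (beyond the scatter) and a number 59 percentage points lower from compound 1 to compound 4 (beyond the scatter) both large, 2-(pyrrolidin-1-yl)ethyl on the saturated chain carbon does not stand in for either 2-amino-1-hydroxyethyl or amino. The count of hydrogen-bond donors does not sort these compounds on its own, since the group leaving compound 3 has 2 and the group entering compound 4 has 0, yet both compounds stand far under compound 1 and compound 2.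

As far as these compounds go, whether the fall in compound 4 goes with the pyrrolidine ring or with the chain itself stays open, and a 3-aminopropyl or 3-(dimethylamino)propyl group at the same place would separate the two. Nothing available here gives a reason for the fall in either compound.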